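Replacing a halogenated phenyl with an allyloxyphenyl

This account rests on a few compounds, and the source may have more. Where it says the series, first, only, none or still open, it means among the compounds named here.

Among the compounds with values here, compound 2 `Cc1ccc(S(=O)(=O)NC(=O)Nc2ccccc2C(=O)/C=C/c2cccc(Br)c2)cc1` holds the lower of the two numbers known so far: in an ADME assay on the whole organism for cytotoxicity, with Artemia salina as the target, with a stated time of 24 h (a lower number here means that less compound is needed, a higher number that more compound is needed for the effect), compound 2 gives 4.02 ug/mL, whereas compound 1 `Cc1ccc(S(=O)(=O)NC(=O)Nc2ccccc2C(=O)/C=C/c2ccccc2Cl)cc1` gives 12.8 ug/mL. Within the data shown here, the only measured step, a 3.2-fold lower number from compound 1 to compound 2 (0.50 log units; beyond the scatter), concerned an exchange of one halogenated phenyl for another. Compound 3 `C=CCOc1ccc(/C=C/C(=O)c2ccccc2NC(=O)NS(=O)(=O)c2ccc(C)cc2)cc1` differs from compound 2 by 4-(allyloxy)phenyl in place of 3-bromophenyl on a double-bonded chain carbon bound to a double-bonded chain carbon. Among the measured compounds shown here, no measured step exchanges a halogenated phenyl for an alkoxy-bearing one, so that step guides only loosely; a change within the scatter is expected, a 2.2-fold higher number from compound 2 to compound 3 (0.35 log units; beyond the scatter). Compound 3 is therefore estimated at 9 ug/mL in this assay, within 3 ug/mL to 30 ug/mL.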

Compound 3, concentration for half-maximal effect: 6.11 ug/mL
For compound 3 the middle estimate is 1.5-fold (0.17 log units) above the measured one; the range from low to high includes it.
By their numbers in this assay, from the lowest: compounds 2 and 3 (each within the scatter of the next); then compound 1.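

In this assay this place on a double-bonded chain carbon bound to a double-bonded chain carbon also tolerates a group without halogen: 4-(allyloxy)phenyl and 3-bromophenyl cannot be told apart (a 1.5-fold higher number from compound 2 to compound 3 (0.18 log units; within the scatter)). Set against 2-chlorophenyl, the same 4-(allyloxy)phenyl gives a modest step (a 2.1-fold lower number from compound 1 to compound 3 (0.32 log units; beyond the scatter)). No evidence at hand explains these numbers. The compounds shown leave open whether a plain phenyl, a 4-methoxyphenyl or a pyridine ring at this place would fall in the same range. They also leave open whether the allyl double bond matters.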